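Swapping trifluoromethyl for iodo on the shared core

The source may report more compounds than this note shows. Statements on the series, on what has been measured and on what is new or still open speak of the compounds shown alone.

Measured compounds:
compound 1 `O=C1O/C(=C\Cn2cc(C(F)(F)F)c(=O)[nH]c2=O)C(OCc2ccccc2)=C1OCc1ccccc1` — 1000 nM
compound 2 `O=C1O/C(=C\Cn2cnc3c(-n4cccc4)ncnc32)C(OCc2ccccc2)=C1OCc1ccccc1` — 4000 nM

In a functional assay on HEL cells (Homo sapiens) for cytotoxicity (on this read-out higher numbers stand for weaker inhibition and lower numbers for stronger inhibition), compound 1 gives the lower of the two numbers; compound 2 sits at a higher value, and the gap between the two lies beyond the usual scatter. The unmeasured compound 3 `O=C1O/C(=C\Cn2cc(I)c(=O)[nH]c2=O)C(OCc2ccccc2)=C1OCc1ccccc1` keeps the core of compound 1 and differs from it in one place: iodo in place of trifluoromethyl on an aromatic carbon.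

Going by the values given here, with no measured pair of this kind to lean on, only a small step is expected here, a 1.5-fold higher number from compound 1 to compound 3 (0.18 log units; within the scatter), which may well stay within the scatter. Compound 3 is therefore estimated at 1500 nM, in a range from 500 nM to 5000 nM.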

Compound 3, half-maximal inhibitory concentration: 3000 nM
Estimate against measurement, compound 3: 2.0-fold (0.30 log units) below; the range from low to high includes it.
By their numbers in this assay, from the lowest: compound 1; then compounds 3 and 2 (each within the scatter of the next).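

Replacing trifluoromethyl with iodo on this aromatic carbon gives a 3.0-fold higher number from compound 1 to compound 3 (0.48 log units; beyond the scatter) in this assay so what this position carries does affect the number. Going by these compounds alone, this is the first comparison here in which only one place on the shared core differs, with a group of four heavy atoms giving way to a single iodine. No measurement shown here accounts for the rise.

On these data alone, how an amine or a methyl on the same carbon would compare with trifluoromethyl remains open. So does whether the step would hold on a different core.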